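Fluorine Added to a Chlorinated Chromone Dithiazole

A few compounds are considered here, and "the series" means these few. Any claim that something is new, unique, unknown or untested is made for them only; others in the source may bear on it.

Of the compounds shown here, three have been measured in a functional assay on PC-3 cells (Homo sapiens) for inhibition, read by sulforhodamine B assay, with a stated time of 48 h, tested at 100 uM; on this read-out lower numbers stand for less inhibition of growth and higher numbers for more inhibition of growth at the one concentration tested. Compound 1 `O=c1c(C2N=C(c3ccccc3)SS2)coc2cc(Cl)ccc12` gives the highest of the three numbers, 81%. Compound 2 `O=c1c(C(=S)Nc2ccccc2)coc2ccccc12` gives 63% in this assay, and compound 3 `O=c1c(C(=S)Nc2ccccc2)coc2ccc(F)cc12` gives 45%. Compound 2 and compound 3 share one core, and the difference between them is fluoro in place of hydrogen on an aromatic carbon, which produces a number 18 percentage points lower from compound 2 to compound 3 (beyond the scatter). How the core of compound 1 differs from the core of compound 2 is not broken down here; their two values simply show compound 1 higher by a margin beyond the scatter.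

Compound 4 `O=c1c(C2N=C(c3ccccc3)SS2)coc2cc(Cl)c(F)cc12` has not yet been measured. It differs from compound 1 by fluoro in place of hydrogen on an aromatic carbon. Among the compounds with values here, this is the same kind of change as the one from compound 2 to compound 3, but not the same: in compound 4 the entering fluoro sits ortho to a chloro group, whereas in compound 3 no such group stands around the place. Within the data shown here, the only guide is the single earlier step, which lies on a different core, so the expectation carries a wide range. Compound 4 is expected to lose ground against compound 1 by a number 16 percentage points lower from compound 1 to compound 4 (beyond the scatter), an estimate that rests on the step of a number 18 percentage points lower from compound 2 to compound 3 (beyond the scatter). In this assay compound 4 is therefore estimated at 65%, with a plausible span from 45% to 82%.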

Compound 4, percent growth inhibition at one concentration: 76%
For compound 4 the middle estimate is 11 percentage points below the measured one; the range from low to high includes it.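

In this assay, fluoro in place of hydrogen on an aromatic carbon gives a number 5 percentage points lower from compound 1 to compound 4 (within the scatter), so on the core of compound 1 this change leaves no reading that can be told apart from no change at all. Set beside the earlier step on the core of compound 2, the result gives no sign that the two cores answer differently to this change, since the gap between the two steps does not exceed what two such steps can show by chance: the same change on two cores in this assay, a number 18 percentage points lower (beyond the scatter) from compound 2 to compound 3 and a number 5 percentage points lower (within the scatter) from compound 1 to compound 4, 13 percentage points apart, within the scatter of two such steps. Within the data shown here, this does not prove that the change carries over unchanged, for there are only two steps, each read at one concentration, and they differ both in core and in surroundings, since the entering fluoro stands ortho to a chloro group only in compound 4.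

The compounds shown leave open whether the step on the core of compound 2 would read the same with a chloro group ortho to the entering fluoro, which would separate the effect of the core from that of the surroundings. They also leave open how a methoxy group or an amine would read in place of that fluoro on the core of compound 1.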